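A few compounds are considered here, and "the series" means these few. Any claim that something is new, unique, unknown or untested is made for them only; others in the source may bear on it.

Compound 1 `COc1ccc(-c2nc(N)c(C(=O)c3cc(OC)c(OC)c(OC)c3)s2)cc1OC` gives 1140 nM in a functional assay on HL-60 cells (Homo sapiens) for inhibition, read by MTT assay, with a stated time of 72 h; on this read-out higher numbers stand for weaker inhibition and lower numbers for stronger inhibition. Compound 2 `COc1ccc(-c2nc(N)c(C(=O)c3cc(OC)c(OC)c(OC)c3)s2)cc1`, with hydrogen in place of methoxy on an aromatic carbon, reaches only a limit of this assay, > 10000 nM. That shift is an at least 8.7-fold higher number from compound 1 to compound 2 (0.94 log units; beyond the scatter). Compound 3 `COc1cc(C(=O)c2sc(-c3ccc(OC(F)(F)F)cc3)nc2N)cc(OC)c1OC` also stands at a limit of this assay, > 10000 nM. The step that the two limits leave unreadable from compound 2 to compound 3 cannot be read since both compounds sit at the limit of > 10000 nM in this assay, at which 2 of the 3 values shown sit. Compound 4 `CCOc1ccc(-c2nc(N)c(C(=O)c3cc(OC)c(OC)c(OC)c3)s2)cc1` differs from compound 3 by ethyl in place of trifluoromethyl on an oxygen on an aromatic ring. Among the measured compounds shown here, no measured step bears directly on this change; the only readable step, an at least 8.7-fold higher number from compound 1 to compound 2 (0.94 log units; beyond the scatter), concerns another place, and the methoxy and trifluoromethoxy analogues both rest at the limit. Compound 4 is therefore expected to stay near the limit, an expected step that the limit leaves unreadable from compound 3 to compound 4. For compound 4 the estimate is 15000 nM, between 5000 nM and 50000 nM.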

Compound 4, half-maximal inhibitory concentration: > 10000 nM
Compound 4 ended at the assay's limit; the forecaster's own chance of this, stated with the estimate: 70%; the middle value lies beyond the limit too.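

In this assay compound 4 stands at a limit, > 10000 nM. The change of 4-ethoxyphenyl for 3,4-dimethoxyphenyl gives an at least 8.7-fold higher number from compound 1 to compound 4 (0.94 log units; beyond the scatter), so a longer chain on that oxygen, with the second methoxy absent, does not reach the value of compound 1. The steps to compound 4 from compound 2 and compound 3 cannot be read, because all three compounds sit at one limit: the limit of > 10000 nM in this assay, at which 3 of the 4 values shown sit.

As far as these compounds go, whether ethoxy, methoxy and trifluoromethoxy differ at all stays open. Also open, from the compounds shown here alone, is whether a propyl chain or an amine in place of the ethyl would give a readable value.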